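This account rests on a few compounds, and the source may have more. Where it says the series, first, only, none or still open, it means among the compounds named here.

Compound 1 `O=Cc1ccc(-c2cn3ccnc3c(-c3ccc4ncn(C5CCCCC5)c4c3)n2)cc1`: 32%
Compound 2 `Fc1ccc(-c2cn3ccnc3c(-c3ccc4ncn(C5CCCCC5)c4c3)n2)cc1`: 7.94%
Compound 3 `COc1ccccc1-c1cn2ccnc2c(-c2ccc3ncn(C4CCCCC4)c3c2)n1`: 21%

In a functional assay on U-251 cells (Homo sapiens) for inhibition, read by sulforhodamine B assay, with a stated time of 48 h, tested at 10 uM (on this read-out higher numbers stand for more inhibition at the one concentration tested (going by the name of the read-out) and lower numbers for less inhibition), compound 3 stands second highest of the three numbers: a number 11 percentage points lower from compound 1 to compound 3 (beyond the scatter), while a number 13.1 percentage points higher from compound 2 to compound 3 (beyond the scatter). Compound 4 `FC(F)(F)c1cccc(-c2cn3ccnc3c(-c3ccc4ncn(C5CCCCC5)c4c3)n2)c1` carries a different group on the shared core: 3-(trifluoromethyl)phenyl in place of 2-methoxyphenyl on an aromatic carbon. Among the measured compounds shown here, no measured step swaps in a trifluoromethyl-bearing ring, so the three steps at this same position are the only guide; they are all modest, the largest being a number 24.1 percentage points lower from compound 1 to compound 2 (beyond the scatter). Taking the spread among compounds 1, 2 and 3, a modest fall or a step within the scatter seems likeliest for compound 4. Compound 4 is therefore expected to give about 15%, between 3% and 30%, which is an expected step of a number 6 percentage points lower from compound 3 to compound 4 (within the scatter).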

Compound 4, a percentage reported as inhibition, at one concentration (the size of the read-out at that concentration, not a potency): 5.93%
Beside the measured number, compound 4's estimate is 9.1 percentage points above it, and the stated range covers the measured number.
By their numbers in this assay, from the lowest: compounds 4 and 2 (each within the scatter of the next); then compound 3; then compound 1.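

In this assay the new group gives a number 15.1 percentage points lower from compound 3 to compound 4 (beyond the scatter) and a number 26.1 percentage points lower from compound 1 to compound 4 (beyond the scatter) as well. Against the 4-fluorophenyl group the result is a number 2 percentage points lower from compound 2 to compound 4 (within the scatter) and so no separation, which means two differently substituted phenyl rings now sit together at the low end, with 4-formylphenyl and 2-methoxyphenyl both clear of 3-(trifluoromethyl)phenyl. Nothing available explains these differences. Still open, as far as these compounds go, is how this position would respond to a phenyl ring carrying an amine or a carboxylic acid, or to a longer chain in place of the ring.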